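Replacing a trihydroxyphenyl group with 4-bromophenyl

The compounds below may be only part of what the source reports. "The series", "measured", "known", "first", "only" and "open" are said of these compounds alone.

compound 1 `Cc1ccc(CS/C(=C/c2ccc(O)cc2)C(=O)c2ccc(Cl)cc2)cc1`: 10000 nM
compound 2 `Cc1ccc(S/C(=C/c2ccc(Br)cc2)C(=O)c2ccc(Cl)cc2)cc1`: 25000 nM
compound 3 `Cc1ccc(CS/C(=C/c2ccc(O)c(O)c2O)C(=O)c2ccc(Cl)cc2)cc1`: 50000 nM

In a functional assay on DU-145 cells (Homo sapiens) for inhibition, read by trypan blue exclusion, with a stated time of 96 h (a lower number here means a stronger inhibitor of growth, a higher number a weaker inhibitor of growth), compound 3 gives 50000 nM. This number lies within the usual scatter of the value for compound 2, so those two cannot be ranked, while the number for compound 1 is clearly lower.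

Compound 4 `Cc1ccc(CS/C(=C/c2ccc(Br)cc2)C(=O)c2ccc(Cl)cc2)cc1` has not yet been measured. It differs from compound 3 in one place: 4-bromophenyl in place of 2,3,4-trihydroxyphenyl on a double-bonded chain carbon bound to a double-bonded chain carbon. Here 4-bromophenyl stands in place of 2,3,4-trihydroxyphenyl on a double-bonded chain carbon bound to a double-bonded chain carbon.

Among the compounds with values here, only one measured step touches this place: putting 2,3,4-trihydroxyphenyl in place of 4-hydroxyphenyl gave a 5.0-fold higher number from compound 1 to compound 3 (0.70 log units; beyond the scatter). That step is modest but beyond the scatter. Compound 2 also carries 4-bromophenyl but differs elsewhere, and it gives 25000 nM, so it is only a loose guide. Within the data shown here, no measured pair shows this exact swap.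

Leaving the 2,3,4-trihydroxyphenyl group behind may therefore undo a similar amount, so a lower number is expected in this assay. The expected change is a 4.2-fold lower number from compound 3 to compound 4 (0.62 log units; beyond the scatter). Compound 4 is expected at 12000 nM, with an estimated range of 4000 nM to 35000 nM.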

Compound 4, concentration for 50% growth inhibition: 10000 nM
The estimate for compound 4 lay 1.2-fold (0.08 log units) above the measured number; the measured number falls inside the stated range.
By their numbers in this assay, from the lowest: compounds 1 and 4 (each within the scatter of the next); then compounds 2 and 3 (each within the scatter of the next).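

In this assay, within the data shown here, the direct swap of 2,3,4-trihydroxyphenyl for 4-bromophenyl gives a 5.0-fold lower number from compound 3 to compound 4 (0.70 log units; beyond the scatter), so this is the first measured pair to show the swap itself, and the group on this double-bonded chain carbon clearly matters. Exchanging bromo for hydroxy on the aromatic carbon gives no change at the digits printed from compound 1 to compound 4 (within the scatter), so a ring with one hydroxy group and a ring with one bromo group cannot be told apart here, and among these compounds only the 2,3,4-trihydroxyphenyl ring stands out from them. With 4-bromophenyl held constant, the group on sulfur also counts: 4-methylbenzyl in place of 4-methylphenyl gives a 2.5-fold lower number from compound 2 to compound 4 (0.40 log units; beyond the scatter), which turns compound 2 from a loose guide into a measured step at a second place in the molecule.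

The compounds shown offer no measured explanation for any of these differences. On these data alone, it remains open whether an amine or a carboxylic acid on this aromatic ring, or a longer chain than the benzyl link on sulfur, would move the number further from that of compound 4.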